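From fluoro to methoxy in the series

The source may report more compounds than this note shows. Statements on the series, on what has been measured and on what is new or still open speak of the compounds shown alone.

- compound 1 `Clc1ccc(Nc2nc(Nc3cn[nH]c3)ncc2Cl)cc1`: 1700 nM
- compound 2 `Clc1cnc(Nc2cn[nH]c2)nc1Nc1ccccc1`: > 8300 nM, which is a limit
- compound 3 `Fc1ccc(Nc2nc(Nc3cn[nH]c3)ncc2Cl)cc1`: 1860 nM
- compound 4 `COc1ccc(Nc2nc(Nc3cn[nH]c3)ncc2Cl)cc1`: not yet measured

All values come from a functional assay on K562 cells (Homo sapiens) for antiproliferative activity, read by MTT assay, with a stated time of 48 h; on this read-out lower numbers stand for stronger inhibition and higher numbers for weaker inhibition. Among the measured compounds shown here, compound 3 gives 1860 nM, and the only other numerical value lies within the scatter of it: a 1.1-fold higher number from compound 1 to compound 3 (0.04 log units; within the scatter). The next change is methoxy in place of fluoro on an aromatic carbon, para to a large group. For the measured compounds named here, two measured steps bear on it. Fluoro in place of chloro gave a 1.1-fold higher number from compound 1 to compound 3 (0.04 log units; within the scatter), while hydrogen in place of chloro gave an at least 4.8-fold higher number from compound 1 to compound 2 (0.68 log units; beyond the scatter). Neither step involves methoxy, so only a small move towards higher numbers is expected: a 1.5-fold higher number from compound 3 to compound 4 (0.18 log units; within the scatter). Compound 4 is estimated at 2800 nM, with an expected range of 1100 nM to 8000 nM.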

Compound 4, half-maximal inhibitory concentration: 2080 nM
Beside the measured number, compound 4's estimate is 1.3-fold (0.13 log units) above it, within the range that was stated.
By their numbers in this assay, from the lowest: compounds 1, 3 and 4 (each within the scatter of the next). At a limit, above all of these: compound 2.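

In this assay, methoxy on this aromatic carbon, para to a large group, stays level with both halogens, with a 1.1-fold higher number from compound 3 to compound 4 (0.05 log units; within the scatter) and a 1.2-fold higher number from compound 1 to compound 4 (0.09 log units; within the scatter) alike, although it carries a hydrogen-bond acceptor that fluoro lacks. Hydrogen at the same place remains apart from all three substituents, with an at least 3.9-fold lower number from compound 2 to compound 4 (0.60 log units; beyond the scatter) as its step to methoxy. The value of compound 2 is a limit: the limit of > 8300 nM in this assay, at which 1 of the 4 values shown sits.

As far as these compounds go, whether an amine, a carboxylic acid or a longer chain such as butoxy at this place would stay level with these groups remains open. Also open, from the compounds shown here alone, is how changes elsewhere on the shared core would read against these values.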